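From piperidin-1-yl to 4-hydroxypiperidin-1-yl in compound 1

This account rests on a few compounds, and the source may have more. Where it says the series, first, only, none or still open, it means among the compounds named here.

For the measured compounds named here, in an ADME assay on L6 cells (Rattus norvegicus) for cytotoxicity (on this read-out higher numbers stand for weaker inhibition and lower numbers for stronger inhibition), compound 1 (`CN(C)C12CC(OC(=O)CN3CCCCC3)C(C(c3ccccc3)C1)C(c1ccccc1)C2`) gives 29300 nM, the higher of the two numbers measured so far. The other measured analogue, compound 2 (`O=C(CN1CCCCC1)OC1CC2(N3CCCC3)CC(c3ccccc3)C1C(c1ccccc1)C2`), gives 14200 nM. The next compound to be tested is compound 3 (`CN(C)C12CC(OC(=O)CN3CCC(O)CC3)C(C(c3ccccc3)C1)C(c1ccccc1)C2`), which differs from compound 1 in a single place: hydroxy in place of hydrogen on a saturated ring carbon. Hydroxy stands in place of hydrogen on a saturated ring carbon, so that piperidin-1-yl becomes 4-hydroxypiperidin-1-yl.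

Going by the values given here, only one measured step bears on this change, and only indirectly. It is a 2.1-fold lower number from compound 1 to compound 2 (0.31 log units; beyond the scatter), a modest step that just exceeds the usual scatter and replaces dimethylamino with pyrrolidin-1-yl, leaving the piperidin-1-yl group untouched. Among the compounds with values here, no measured step shows what a change on that ring does in this assay, so the direction remains uncertain. A modest move of similar size towards a higher number is the tentative expectation, and a result within the scatter would be no surprise. The expected step is a 1.2-fold higher number from compound 1 to compound 3 (0.09 log units; within the scatter). For compound 3, the estimated value is 36000 nM, with an expected range of 14000 nM to 90000 nM.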

Compound 3, half-maximal inhibitory concentration: 102000 nM
Compound 3: middle estimate off by 2.8-fold (0.45 log units), on the low side; measured number above the stated range.
By their numbers in this assay, from the lowest: compound 2; then compound 1; then compound 3.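

Hydroxy in place of hydrogen on the piperidin-1-yl ring, three ring bonds from the ring nitrogen, gives a 3.5-fold higher number from compound 1 to compound 3 (0.54 log units; beyond the scatter) in this assay and so shows that this ring is not a silent part of compound 1 on this read-out. The number moves towards weaker inhibition, a step that is beyond the scatter and the first shown at this place, whereas the only earlier step, a 2.1-fold lower number from compound 1 to compound 2 (0.31 log units; beyond the scatter) at the dimethylamino group, left the ring untouched and ran in the opposite direction. Nothing measured on these compounds accounts for the rise, which therefore stands as an observation for this single pair.

What an amino group, a methoxy group or a carboxylic acid would do at the same place on the ring stays open, so the compounds shown cannot tell whether the step belongs to hydroxy alone or to any replacement of hydrogen there. Going by these compounds, it also stays open whether 4-hydroxypiperidin-1-yl would raise the number by a similar step in compound 2, where pyrrolidin-1-yl stands in place of dimethylamino.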